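Swapping Nitro for Chloro on the Aryl Hydrazone

A few compounds are considered here, and "the series" means these few. Any claim that something is new, unique, unknown or untested is made for them only; others in the source may bear on it.

Compound 1 `CC1=CC[C@@H]([C@@](C)(O)CCCC(C)(C)NC(=S)N/N=C\c2ccccc2)CC1`: 36200 nM
Compound 2 `CC1=CC[C@@H]([C@@](C)(O)CCCC(C)(C)NC(=S)N/N=C\c2ccc(N(C)C)cc2)CC1`: > 100000 nM
Compound 3 `CC1=CC[C@@H]([C@@](C)(O)CCCC(C)(C)NC(=S)N/N=C\c2cccc([N+](=O)[O-])c2)CC1`: 20700 nM

In a functional assay on PCO3 cells (Homo sapiens) for cytotoxicity, read by sulforhodamine B assay (on this read-out higher numbers stand for weaker inhibition of growth and lower numbers for stronger inhibition of growth), compound 1 gives 36200 nM. Compound 2 reaches only the assay limit of > 100000 nM. Compound 3 gives 20700 nM, the smaller of the two numbers shown, at a gap from compound 1 of a 1.7-fold lower number from compound 1 to compound 3 (0.24 log units; within the scatter) that lies within the scatter. The step of an at least 4.8-fold lower number from compound 2 to compound 3 (0.68 log units; beyond the scatter) lies beyond the scatter. Compound 4 `CC1=CC[C@@H]([C@@](C)(O)CCCC(C)(C)NC(=S)N/N=C\c2cccc(Cl)c2)CC1` differs from compound 3 by chloro in place of nitro on an aromatic carbon. Among the measured compounds shown here, no measured step involves a chloro group; the nearest comparison, a 1.7-fold lower number from compound 1 to compound 3 (0.24 log units; within the scatter), shows the nitro group itself shifting the number only within the scatter, so the move to chloro is expected to stay within the scatter too: a 1.2-fold higher number from compound 3 to compound 4 (0.08 log units; within the scatter). Compound 4 is accordingly estimated at 25000 nM, between 10000 nM and 65000 nM.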

Compound 4, concentration for total growth inhibition: 37800 nM
Compound 4: middle estimate off by 1.5-fold (0.18 log units), on the low side; low and high end bracket the measured number.
By their numbers in this assay, from the lowest: compounds 3, 1 and 4 (each within the scatter of the next). At a limit, above all of these: compound 2.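

In this assay, chloro on this aromatic carbon cannot be told apart from nitro, a 1.8-fold higher number from compound 3 to compound 4 (0.26 log units; within the scatter), or from hydrogen, a 1.0-fold higher number from compound 1 to compound 4 (0.02 log units; within the scatter). Among compounds 1, 3 and 4, then, the three groups at this place give numbers within the scatter of one another. The step of an at least 2.6-fold lower number from compound 2 to compound 4 (0.42 log units; beyond the scatter) lies beyond the scatter, but it starts from a limit: the limit of > 100000 nM in this assay, at which 1 of the 4 values shown sits.

From the compounds shown here alone, what a methoxy group or a carboxylic acid would give on this aromatic carbon stays open. So does the effect of a shorter chain in the shared core.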